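The source may report more compounds than this note shows. Statements on the series, on what has been measured and on what is new or still open speak of the compounds shown alone.

In a functional assay on K562 cells (Homo sapiens), read by MTT assay, with a stated time of 72 h (on this read-out lower numbers stand for stronger inhibition and higher numbers for weaker inhibition), compound 1 `C#Cc1cn([C@@H]2O[C@H](CO)[C@@H](O)[C@H]2O)c2ncnc(C)c12` gives 110 nM as its result. Compound 2 `O=c1[nH]cnc2c1c(-c1ccccc1)cn2[C@@H]1O[C@H](CO)[C@@H](O)[C@H]1O` is reported only as the limit > 20000 nM and has no exact number. Compound 3 `O=c1[nH]cnc2c1c(-c1cc3ccccc3o1)cn2[C@@H]1O[C@H](CO)[C@@H](O)[C@H]1O` likewise has only the limit > 20000 nM to show. Compound 2 therefore stands at the limit of > 20000 nM in this assay, at which 2 of the 3 values shown sit, and nothing finer can be said of it. The change to compound 4 `Nc1nc2c(c(-c3ccccc3)cn2[C@@H]2O[C@H](CO)[C@@H](O)[C@H]2O)c(=O)[nH]1` is amino in place of hydrogen on an aromatic carbon and it lies between two ring nitrogen atoms. Going by the values given here, the one measured step nearby is a step that the two limits leave unreadable from compound 2 to compound 3 and it offers no size to carry over. In this assay no clear change is therefore expected, and the estimated step is a number no higher from compound 2 to compound 4 (the limit leaves the size open) overall. Compound 4 is expected between 8000 nM and 40000 nM around a middle of 20000 nM as an estimate.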

Compound 4, half-maximal inhibitory concentration: > 20000 nM
Compound 4: no number, only a limit (the forecaster's own chance of this, stated with the estimate: 80%); the middle value lies on the limit itself.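

Compound 2 and compound 4 both have only a limit in this assay, and the step between them cannot be read. The compounds shown leave open whether amino in place of hydrogen changes the inhibition at all.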